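The source may hold more compounds than are shown below. What is called first, only, known or untested is meant among the compounds shown, and "the series" means these compounds.

Compound 2, `CCCCCCCN(CCCCCSc1[nH]cnc2ncnc1-2)C(=O)Nc1ccc(F)cc1F`, is the stronger of the two measured compounds in an assay on microsomes from liver for inhibition of sterol O-acyltransferase 1 (Rattus norvegicus); on this read-out higher numbers stand for weaker inhibition and lower numbers for stronger inhibition: compound 2 gives 200 nM, while compound 1, `CCCCCCCN(CCCCCSc1nc(N)c2c[nH]nc2n1)C(=O)Nc1ccc(F)cc1F`, gives 4230 nM in this assay. Within the data shown here, the one measured step, a 21-fold lower number from compound 1 to compound 2 (1.33 log units; beyond the scatter), replaces the aromatic group attached to the sulfur, showing that this position can move the read-out a long way. Compound 3, `CCCCCCCN(CCCCCSc1n[nH]c(-c2ccccc2)n1)C(=O)Nc1ccc(F)cc1F`, changes the same position: a group of 11 heavy atoms (8 carbon, 3 nitrogen; one five-membered aromatic ring with 3 hetero atoms, one six-membered aromatic ring of carbon only) in place of a group of 9 heavy atoms (5 carbon, 4 nitrogen; one five-membered aromatic ring with 2 hetero atoms, one six-membered aromatic ring with 2 hetero atoms), on a sulfur. Among the measured compounds shown here, the only step that bears on it is the large one from compound 1 to compound 2, so a sizeable shift in this assay is plausible, but its direction cannot be read from that step alone. For compound 3 a weaker result than compound 2 is expected, with the step of a 5.0-fold higher number from compound 2 to compound 3 (0.70 log units; beyond the scatter) chosen as a cautious middle. The estimate for compound 3 in this assay is 1000 nM, expected to fall between 150 nM and 6000 nM.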

Compound 3, half-maximal inhibitory concentration: 4000 nM
Compound 3: the middle estimate sits 4.0-fold (0.60 log units) below what was measured; measured number inside the range.
By their numbers in this assay, from the lowest: compound 2; then compounds 3 and 1 (each within the scatter of the next).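

Placing 5-phenyl-1H-1,2,4-triazol-3-yl on the sulfur gives a 20-fold higher number from compound 2 to compound 3 (1.30 log units; beyond the scatter) in this assay, so the low number of compound 2 does not carry over to every pair of aromatic rings at this place. Compound 1 and compound 3 carry clearly different groups here, yet a 1.1-fold lower number from compound 1 to compound 3 (0.02 log units; within the scatter) leaves them indistinguishable, and among these three compounds only the group of compound 2 stands apart. Nothing measured here explains these differences.

Still open, as far as these compounds go, is whether the carbon-only phenyl ring of compound 3 matters, which a plain 1H-1,2,4-triazol-3-yl group on the sulfur would test. It is also unknown how a single ring, such as an imidazole or a pyridine, would compare with the two-ring group of compound 2.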